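The compounds below may be only part of what the source reports. "The series", "measured", "known", "first", "only" and "open" are said of these compounds alone.

Measured so far in a functional assay on MGC-803 cells (Homo sapiens) for antiproliferative activity, read by MTT assay, with a stated time of 72 h; a higher number here means a weaker inhibitor, a lower number a stronger inhibitor:
- Compound 1 `O=C(N/N=C/c1ccccc1O)c1cccc(S(=O)(=O)N2CCOCC2)c1`: 25300 nM
- Compound 2 `CCN(CC)c1ccc(/C=N/NC(=O)c2cccc(S(=O)(=O)N3CCOCC3)c2)c(O)c1`: 4040 nM

Compound 1 holds the higher of the two numbers, making it the weaker inhibitor of this pair. Compound 3 `O=C(N/N=C/c1cc(Br)ccc1O)c1cccc(S(=O)(=O)N2CCOCC2)c1` keeps the core of compound 1 and differs in one place: bromo in place of hydrogen on an aromatic carbon. The bromo sits para to a hydroxy group, so 2-hydroxyphenyl becomes 5-bromo-2-hydroxyphenyl.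

For the measured compounds named here, only one measured step bears on this change: a 6.3-fold lower number from compound 1 to compound 2 (0.80 log units; beyond the scatter), where diethylamino replaces hydrogen on an aromatic carbon. Going by the values given here, that step involves a different group, and no measured compound carries bromo, so it offers only loose guidance. A modest fall in this assay, smaller than that step, is therefore expected.

Compound 3 is estimated at 12000 nM, with an expected range of 4000 nM to 32000 nM. This estimate corresponds to an expected 2.1-fold lower number from compound 1 to compound 3 (0.32 log units; beyond the scatter).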

Compound 3, half-maximal inhibitory concentration: 14800 nM
Compound 3: middle estimate off by 1.2-fold (0.09 log units), on the low side; measured number inside the range.
By their numbers in this assay, from the lowest: compound 2; then compounds 3 and 1 (each within the scatter of the next).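

In this assay, adding bromo para to a hydroxy group gives a 1.7-fold lower number from compound 1 to compound 3 (0.23 log units; within the scatter) and so does not separate compound 3 from compound 1, whereas the diethylamino change on the same core gives a 6.3-fold lower number from compound 1 to compound 2 (0.80 log units; beyond the scatter) and does exceed the scatter. Within this small set, then, a substitution on this ring does not by itself guarantee a shift in the number, and the single bromine atom at this position leaves the result of the 2-hydroxyphenyl parent in place. No measurement is available that would explain this result.

The compounds shown leave open whether another group at this position, such as methoxy, nitro or a carboxylic acid, would move the number beyond the scatter. They also leave open whether bromo and diethylamino together would behave like diethylamino alone.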